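Leaving 5-chloro-2-hydroxyphenyl for furan-2-yl

A few compounds are considered here, and "the series" means these few. Any claim that something is new, unique, unknown or untested is made for them only; others in the source may bear on it.

In a functional assay on BGC-823 cells (Homo sapiens) for cytotoxicity, read by MTT assay, with a stated time of 48 h (a higher number here means a weaker inhibitor, a lower number a stronger inhibitor), compound 1 (`O=C(CSc1nnc(-c2ccncc2)o1)N/N=C/c1ccc(Br)cc1`) gives 24500 nM and compound 2 (`COc1cccc(/C=N/NC(=O)CSc2nnc(-c3ccncc3)o2)c1`) gives 15800 nM, a gap within the scatter: a 1.6-fold lower number from compound 1 to compound 2 (0.19 log units; within the scatter). Compound 3 (`O=C(CSc1nnc(-c2ccncc2)o1)N/N=C/c1cc(Cl)ccc1O`) has the lowest number of the three, 5470 nM. Compound 4 (`O=C(CSc1nnc(-c2ccncc2)o1)N/N=C/c1ccco1`) carries furan-2-yl in place of 5-chloro-2-hydroxyphenyl on a carbon with a double bond to nitrogen. All measured steps changed this same place, and the two that introduced 5-chloro-2-hydroxyphenyl were modest: a 4.5-fold lower number from compound 1 to compound 3 (0.65 log units; beyond the scatter) and a 2.9-fold lower number from compound 2 to compound 3 (0.46 log units; beyond the scatter). Losing that group is therefore expected to raise the number by a similar amount in this assay. The expected step is a 2.6-fold higher number from compound 3 to compound 4 (0.41 log units; beyond the scatter). For compound 4 the estimated value is 14000 nM, with an expected range of 6000 nM to 32000 nM.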

Compound 4, half-maximal inhibitory concentration: 25800 nM
Compound 4: the middle estimate sits 1.8-fold (0.27 log units) below what was measured; low and high end bracket the measured number.
By their numbers in this assay, from the lowest: compound 3; then compounds 2, 1 and 4 (each within the scatter of the next).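

In this assay, replacing 5-chloro-2-hydroxyphenyl with furan-2-yl gives the first measured step away from that group (a 4.7-fold higher number from compound 3 to compound 4 (0.67 log units; beyond the scatter)), and it returns the number to the level of the other two compounds. The steps from the other two groups stay within the scatter (a 1.6-fold higher number from compound 2 to compound 4 (0.21 log units; within the scatter); a 1.1-fold higher number from compound 1 to compound 4 (0.02 log units; within the scatter)), so among these four groups on this carbon, only 5-chloro-2-hydroxyphenyl stands apart. Nothing measured here accounts for that difference.

The compounds shown leave open whether the hydroxy group or the chlorine accounts for the lower number of compound 3. They also leave open how an amine or a carboxylic acid would fare at this position.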